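Compound 3: hydrogen in place of methoxy

The source may report more compounds than this note shows. Statements on the series, on what has been measured and on what is new or still open speak of the compounds shown alone.

For the measured compounds named here, in a functional assay on HeLa cells (Homo sapiens) for antiproliferative activity, read by cell counting, with a stated time of 2 days (a higher number here means a weaker inhibitor, a lower number a stronger inhibitor), neither compound tested so far gives a number. Compound 1 `COc1cc(C(=O)c2sc(N(C)Cc3ccccc3)nc2N)cc(OC)c1OC` gives > 200000 nM, which is a limit of the assay. Compound 2 `COc1ccc(C(=O)c2sc(N3CCCC3)nc2N)cc1` gives > 200000 nM, which is also a limit. Compound 2 therefore has no measured potency, and the data so far consist of the limit of > 200000 nM in this assay, at which 2 of the 2 values shown sit.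

Compound 3 `Nc1nc(N2CCCC2)sc1C(=O)c1ccccc1` differs from compound 2 by hydrogen in place of methoxy on an aromatic carbon, para to a large group: hydrogen in place of methoxy on an aromatic carbon. No measured pair sizes this change. With compound 2 at the limit of > 200000 nM, no step beyond the scatter is expected in this assay, and a further reading at the limit is the likeliest outcome. The estimated change is an at least 1.1-fold lower number from compound 2 to compound 3 (0.04 log units; that floor lies within the scatter). For compound 3 the expected value is 180000 nM, with an estimated range from 60000 nM to 200000 nM.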

Compound 3, half-maximal inhibitory concentration: > 200000 nM
Compound 3: no number, only a limit; the forecaster's own chance of this, stated with the estimate: 70%; middle value at least 1.1-fold (0.04 log units) away from the limit.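

Compound 2 and compound 3 both stand at a limit of the assay, so no step can be read for hydrogen in place of methoxy. The compounds shown leave open whether any change on the shared core gives a measured potency in this assay, because every reading so far is the same limit: the limit of > 200000 nM in this assay, at which 3 of the 3 values shown sit.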